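The source may hold more compounds than are shown below. What is called first, only, known or untested is meant among the compounds shown, and "the series" means these compounds.

Measured in a functional assay on THP-1 cells (Homo sapiens) for inhibition, read by sulforhodamine B assay, with a stated time of 48 h; on this read-out higher numbers stand for weaker inhibition and lower numbers for stronger inhibition:
- compound 1 `COc1ccc(C(c2ccc(OC(C)CN(C)C)cc2)c2cccc3ccccc23)c(OC)c1OC`: 15000 nM
- compound 2 `COc1ccc(C(c2ccc(OCCO)cc2)c2cccc3ccccc23)c(OC)c1OC`: 16600 nM
- compound 3 `COc1ccc(/C(=C\c2ccc(F)cc2)c2cccc3ccccc23)c(OC)c1OC`: 9080 nM

Compound 2, at 16600 nM, cannot be separated from the other two compounds, as all three values lie within the scatter of one another. No order can be drawn among them.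

Compound 4 `COc1ccc(C(OCc2ccc(C)cc2)c2cccc3ccccc23)c(OC)c1OC`, not yet measured, carries (4-methylbenzyl)oxy in place of 4-(2-hydroxyethoxy)phenyl on a saturated chain carbon bound to two aromatic carbons.

Among the measured compounds shown here, the only measured single-place step is a 1.1-fold higher number from compound 1 to compound 2 (0.04 log units; within the scatter). It lies within the scatter, but it concerns a group on an oxygen on an aromatic ring, so it bears on the new change only indirectly. For the measured compounds named here, no measured step covers a replacement at the saturated chain carbon, and the estimate is therefore loose. It rests on the narrow spread of the series, from compound 3 at 9080 nM to compound 2 at 16600 nM. No step beyond the scatter is expected in this assay, and no firm direction can be given. The expected step is a 1.4-fold lower number from compound 2 to compound 4 (0.14 log units; within the scatter). The estimated value for compound 4 is 12000 nM, with an expected range from 5000 nM to 30000 nM.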

Compound 4, half-maximal inhibitory concentration: > 20000 nM
Compound 4 gave a limit, no number (the forecaster's own chance of this, stated with the estimate: 12%); middle value at least 1.6-fold (0.22 log units) away from the limit.
By their numbers in this assay, from the lowest: compounds 3, 1 and 2 (each within the scatter of the next). At a limit, above all of these: compound 4.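

In this assay compound 4 gives a limit and not a number, > 20000 nM. Among the compounds shown here, the saturated chain carbon bound to two aromatic carbons had not been varied in the earlier compounds, and the one change read there, (4-methylbenzyl)oxy in place of 4-(2-hydroxyethoxy)phenyl, comes out as an at least 1.2-fold higher number from compound 2 to compound 4 (0.08 log units; that floor lies within the scatter), so no lower number appears with this change, while no loss can be claimed from a floor of that size. What can be read of this step ends at a limit: the limit of > 20000 nM in this assay, at which 1 of the 4 values shown sits.

The change swaps a group with 1 hydrogen-bond donor and 2 hydrogen-bond acceptors for one with 0 donors and 1 acceptor, and also alters how the aromatic ring is attached, so a single step cannot tell these differences apart. Also open, from the compounds shown here alone, is whether this place can give a measurable number in this assay with other groups, such as a carboxylic acid in place of the methyl of (4-methylbenzyl)oxy, or a longer chain in place of its single carbon link to the oxygen.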